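The compounds below may be only part of what the source reports. "The series", "measured", "known", "first", "only" and "open" are said of these compounds alone.

Measured so far:
compound 1 `Cc1cc(=O)oc2cc(OCc3nc(N)nc(Nc4ccc(F)cc4)n3)ccc12` — 18300 nM in an assay on COS-7 cells for agonist activity at Free fatty acid receptor 1 (Homo sapiens), read by scintillation counting and inositol phosphate accumulation, with a stated time of 90 min; a lower number here means that less compound is needed, a higher number that more compound is needed for the effect
compound 2 `Cc1ccc(Nc2nc(N)nc(COc3ccc4c(C)cc(=O)oc4c3)n2)cc1Cl` — 140 nM in this assay

For the measured compounds named here, compound 2 holds the lowest number of the two; its nearest neighbour is compound 1, and the step between them, a 130-fold lower number from compound 1 to compound 2 (2.12 log units; beyond the scatter), is the only measured step. Compound 3 `Cc1ccc(Nc2nc(N)nc(COc3ccc4c(C)cc(=O)oc4c3)n2)cc1C` is the next member. It differs from compound 2 in one place: methyl in place of chloro on an aromatic carbon.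

Which measured steps bear on this change: only the step from compound 1 to compound 2, and only loosely. That step swapped the whole aryl group on the ring nitrogen and was large, which shows that the substitution pattern on this ring can move the number far. Going by the values given here, no measured pair isolates chloro against methyl at this position, so the size of the coming step cannot be read from the data; the change is small in heavy-atom count and keeps the methyl group of compound 2 in place. For compound 3 a step of modest size is expected, a 2.0-fold higher number from compound 2 to compound 3 (0.30 log units; within the scatter), most likely toward a somewhat higher number but possibly within the scatter. Compound 3 is therefore estimated at 280 nM, with a range from 80 nM to 1000 nM.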

Compound 3, half-maximal effective concentration: 210 nM
Compound 3: the middle estimate sits 1.3-fold (0.12 log units) above what was measured; the measured number falls inside the stated range.
By their numbers in this assay, from the lowest: compounds 2 and 3 (each within the scatter of the next); then compound 1.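

In this assay, methyl in place of chloro on this aromatic carbon, ortho to a methyl group, gives a 1.5-fold higher number from compound 2 to compound 3 (0.18 log units; within the scatter) and leaves compound 2 and compound 3 indistinguishable by this read-out, so at this position in this series, the two groups cannot be told apart. The large step to the 3-chloro-4-methylphenyl group, a 130-fold lower number from compound 1 to compound 2 (2.12 log units; beyond the scatter), now has a counterpart without chlorine: 3,4-dimethylphenyl in place of 4-fluorophenyl gives an 87-fold lower number from compound 1 to compound 3 (1.94 log units; beyond the scatter), which is also large, so among the compounds shown, chlorine is not needed for a large step away from compound 1. No supporting measurement accompanies these numbers to say why chloro and methyl read alike here.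

The compounds shown do not separate what the 4-methyl group contributes to these large steps from what the chloro or methyl group on the neighbouring ring carbon contributes, and the effect of removing that second group stays unknown. Also open, going by these compounds, is how this aromatic carbon would respond to other groups, such as methoxy, trifluoromethyl, an amine, a carboxylic acid or a longer chain such as propyl.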